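Phenyl Addition on Two Benzoate Cores in Monoglyceride Lipase Assay

The source may hold more compounds than are shown below. What is called first, only, known or untested is meant among the compounds shown, and "the series" means these compounds.

Measured compounds:
compound 1 `O=C(OCC1CO1)c1ccccc1`: 0.2%
compound 2 `O=C(OCC1CCCCO1)c1ccccc1`: 24%
compound 3 `O=C(OCC1CCCCO1)c1cccc(-c2ccccc2)c1`: 49%

Three esters have been measured in an assay on membranes from cerebellum for inhibition of Monoglyceride lipase (Rattus norvegicus), tested at 100 uM; a higher number here means more inhibition at the concentration tested (going by the name of the read-out), a lower number less inhibition. Compound 1 gives 0.2%, the lowest of the three numbers; compound 2 gives 24% and compound 3 gives 49%. How the core of compound 1 differs from the core of compound 2 is not broken down here. Between compound 2 and compound 3 the change is phenyl in place of hydrogen on an aromatic carbon, and it produced a step of a number 25 percentage points higher from compound 2 to compound 3 (beyond the scatter).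

Compound 4 `O=C(OCC1CO1)c1ccc(-c2ccccc2)cc1` has not yet been measured in this assay. It differs from compound 1 by phenyl in place of hydrogen on an aromatic carbon. Going by the values given here, this is the same kind of change as the one from compound 2 to compound 3, but not the same: in compound 3 the phenyl sits meta to a large group, whereas in compound 4 it sits para to a group of 7 heavy atoms, and the cores on which the change is made are different.

Among the compounds with values here, on the single precedent, the step from compound 1 to compound 4 is expected to be a number 19.8 percentage points higher from compound 1 to compound 4 (beyond the scatter), somewhat smaller than the step from compound 2 to compound 3, because compound 1 starts from 0.2% and the placement of the phenyl is not the same. Compound 4 is therefore estimated to give 20%, with a plausible range from 2% to 45%.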

Compound 4, a percentage reported as inhibition, at one concentration (the size of the read-out at that concentration, not a potency): 9%
For compound 4 the middle estimate is 11 percentage points above the measured one; the measured number falls inside the stated range.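

In this assay, phenyl in place of hydrogen on an aromatic carbon gave a number 8.8 percentage points higher from compound 1 to compound 4 (within the scatter), so on the core of compound 1 this change cannot be told apart from no change at all. Set beside the earlier step, the change did not carry over at the same size from one core to the other: the same change on two cores in this assay, a number 25 percentage points higher (beyond the scatter) from compound 2 to compound 3 and a number 8.8 percentage points higher (within the scatter) from compound 1 to compound 4, 16.2 percentage points apart, beyond the scatter of two such steps. The phenyl also stands in a different place on the ring in the two steps, so this pair does not show whether the core, the placement or both account for the gap, and two steps set no rule for the series.

The compounds shown leave open what the phenyl would do if its placement were held the same on both cores, which would separate the two differences that are mixed here. They also leave open whether another group in that place, such as an amine or a carboxylic acid, would give a step beyond the scatter on the core of compound 1, or would behave alike on both cores.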